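The compounds below may be only part of what the source reports. "The series", "measured", "known", "first", "only" and "open" are said of these compounds alone.

Measured compounds:
compound 1, `O=C1/C(=C/c2ccccc2F)CN(S(=O)(=O)c2ccc(Cl)cc2)C/C1=C\c1ccccc1F`, in a functional assay on SMMC-7721 cells (Homo sapiens) for cytotoxicity, read by MTT assay, with a stated time of 24 h (on this read-out lower numbers stand for stronger inhibition and higher numbers for weaker inhibition), compound 1 gives 4500 nM
compound 2, `N#Cc1ccc(S(=O)(=O)N2C/C(=C\c3ccccc3F)C(=O)/C(=C/c3ccccc3F)C2)cc1`, in this assay compound 2 gives 14600 nM

Of the two numbers in this assay, compound 2 stands at the higher one; its nearest neighbour is compound 1, and the step of a 3.2-fold higher number from compound 1 to compound 2 (0.51 log units; beyond the scatter) separates them. Compound 3, `CC(=O)Nc1ccc(S(=O)(=O)N2C/C(=C\c3ccccc3F)C(=O)/C(=C/c3ccccc3F)C2)cc1`, has not yet been measured in this assay. It differs from compound 2 in one place: acetamido in place of cyano on an aromatic carbon. Among the compounds with values here, only one measured step exists, and it concerns the same aromatic carbon, but it exchanges chloro for cyano rather than cyano for acetamido, so it bears on compound 3 only loosely. That step, a 3.2-fold higher number from compound 1 to compound 2 (0.51 log units; beyond the scatter), shows that the group on this carbon can move the number by a modest amount. Nothing measured here tells how acetamido behaves at that place. The author therefore expects compound 3 to give a number close to that of compound 2, with a step of a 1.2-fold higher number from compound 2 to compound 3 (0.09 log units; within the scatter) that may not exceed the scatter, and estimates for compound 3 a value of 18000 nM, ranging from 7000 nM to 45000 nM.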

Compound 3, half-maximal inhibitory concentration: 7500 nM
The estimate for compound 3 lay 2.4-fold (0.38 log units) above the measured number, within the range that was stated.
By their numbers in this assay, from the lowest: compounds 1, 3 and 2 (each within the scatter of the next, the first and the last beyond it).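

In this assay, the exchange of cyano for acetamido at this aromatic carbon, which brings 4 heavy atoms in place of 2 and adds a hydrogen-bond donor, gives a 1.9-fold lower number from compound 2 to compound 3 (0.29 log units; within the scatter), so this change cannot be told apart from no change at all. The exchange of chloro for acetamido at the same carbon gives a 1.7-fold higher number from compound 1 to compound 3 (0.22 log units; within the scatter), so compound 3 lies within the scatter of both neighbours, even though those two neighbours are separated by a step beyond it; the position therefore accepts acetamido, and the three compounds together do not order these groups beyond the single difference between chloro and cyano. Nothing available bears on why these groups read as they do.

The compounds shown do not tell how an amine, a carboxylic acid or a longer acyl chain would read on this aromatic carbon. They also leave open whether any group there can reach a number beyond the scatter on the lower side of compound 1, or whether these three values mark the span of the position in this assay.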